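The source may hold more compounds than are shown below. What is called first, only, known or untested is meant among the compounds shown, and "the series" means these compounds.

Compound 3 `O=S(=O)(NCCCNCC1COc2ccccc2O1)c1cc(C(F)(F)F)cc(C(F)(F)F)c1` gives 2700 nM in a functional assay on HPAC cells (Homo sapiens) for inhibition, read by MTT assay, with a stated time of 72 h; a lower number here means a stronger inhibitor of growth, a higher number a weaker inhibitor of growth. Among the three compounds with numbers, it stands lowest, though compound 2 `O=S(=O)(NCCNCc1ccc(-c2ccccc2)cc1)c1cc(C(F)(F)F)cc(C(F)(F)F)c1` gives 2800 nM in this assay, a number within the usual scatter of that of compound 3. Compound 1 `O=S(=O)(NCCNCc1cccc2ccccc12)c1cc(C(F)(F)F)cc(C(F)(F)F)c1` gives 18000 nM, a number beyond the scatter away from compound 3. Compound 4 `O=S(=O)(NCCCNCc1cccc(Cl)c1)c1cc(C(F)(F)F)cc(C(F)(F)F)c1` has not yet been measured; it differs from compound 3 by 3-chlorophenyl in place of 2,3-dihydro-1,4-benzodioxin-2-yl on a saturated chain carbon bound to an amine nitrogen. Within the data shown here, no step between measured compounds covers such a change, so the expectation rests only on the spread seen across compounds 1, 2 and 3. A modest rise in the number, of a size near the edge of the scatter, is expected, written as a 1.7-fold higher number from compound 3 to compound 4 (0.22 log units; within the scatter). Compound 4 is estimated at 4500 nM, within a range from 1500 nM to 14000 nM.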

Compound 4, concentration for 50% growth inhibition: 2700 nM
Beside the measured number, compound 4's estimate is 1.7-fold (0.22 log units) above it; measured number inside the range.
By their numbers in this assay, from the lowest: compounds 3, 4 and 2 (each within the scatter of the next); then compound 1.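

There is no change at the digits printed from compound 3 to compound 4 (within the scatter) in this assay when 3-chlorophenyl takes the place of 2,3-dihydro-1,4-benzodioxin-2-yl on a saturated chain carbon bound to an amine nitrogen. Among these compounds, this is the only single-place comparison so far, and it shows that this position accepts the loss of the non-aromatic ring and both hydrogen-bond acceptors without a change beyond the scatter. Nothing available explains this result. Going by these compounds, it remains open whether an unsubstituted phenyl, a pyridine ring or a carboxylic acid at this position would give a similar number. On these data alone, it also remains open how a longer chain would affect the number.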